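Benzyl on the aniline nitrogen across two cores

The source may report more compounds than this note shows. Statements on the series, on what has been measured and on what is new or still open speak of the compounds shown alone.

Measured compounds:
compound 1 `COc1cc(OC)n2cc(-c3ccc(NCc4ccccc4)cc3)nc2n1`; in a functional assay on A549 cells (Homo sapiens) for antiproliferative activity, read by MTT assay, with a stated time of 72 h (a higher number here means a weaker inhibitor of growth, a lower number a stronger inhibitor of growth), compound 1 gives > 100000 nM, a limit of the assay.
compound 2 `COc1cc(OC)n2cc(-c3ccc(N(Cc4ccccc4)Cc4ccccc4)cc3)nc2n1`; in this assay compound 2 gives 7000 nM.
compound 3 `Cc1ccc2nc(-c3ccc(N)cc3)cn2c1`; in this assay compound 3 gives > 100000 nM, a limit of the assay.

Compound 1 and compound 2 share a core and differ by benzyl in place of hydrogen on a nitrogen on an aromatic ring. The step of an at least 14-fold lower number from compound 1 to compound 2 (1.15 log units; beyond the scatter) can only be read as a bound, since compound 1 sits at the limit of > 100000 nM in this assay, at which 2 of the 3 values shown sit. Compound 3 carries another core; the difference between the two cores is not broken down here. Compound 4 `Cc1ccc2nc(-c3ccc(NCc4ccccc4)cc3)cn2c1` is not yet measured and differs from compound 3 by benzyl in place of hydrogen on a nitrogen on an aromatic ring. The places are not the same: in compound 1 the nitrogen's other neighbours are aromatic carbon and saturated chain carbon, in compound 3 only aromatic carbon, so this is the same kind of change, not the same. The single benzyl on the nitrogen of compound 1 left it at the limit. The expected step is an at least 1.2-fold lower number from compound 3 to compound 4 (0.09 log units; that floor lies within the scatter), estimated from compound 1 at > 100000 nM. Compound 4 is expected near 80000 nM, between 15000 nM and 300000 nM, with a fair chance of a limit.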

Compound 4, concentration for 50% growth inhibition: 56100 nM
Beside the measured number, compound 4's estimate is 1.4-fold (0.15 log units) above it; measured number inside the range.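

In this assay the change from amino to benzylamino on the core of compound 3 reads as an at least 1.7-fold lower number from compound 3 to compound 4 (0.25 log units; that floor lies within the scatter) and so gives only a floor that does not clear the scatter. Compound 3 gives > 100000 nM as a limit of the assay, which leaves the full size of this step unread. The change is also not quite the same on the two cores, since the benzyl enters on a nitrogen that already carries a benzyl in compound 1 and on a free amino nitrogen in compound 3, and the notes can show no transfer of the size of the step from one core to the other, only that neither step contradicts the other: the same change on two cores in this assay, an at least 14-fold lower number (1.15 log units; beyond the scatter) from compound 1 to compound 2 and an at least 1.7-fold lower number (0.25 log units; that floor lies within the scatter) from compound 3 to compound 4; the limit leaves it open whether they differ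

Still open, going by these compounds, is whether a second benzyl on the nitrogen of compound 4 would bring a step on this core like the one on the core of compound 1. Also open, on these data alone, is how a methyl or an acetyl group on that nitrogen would read in this assay on either core.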